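The source may report more compounds than this note shows. Statements on the series, on what has been measured and on what is new or still open speak of the compounds shown alone.

The series rests on the core of compound 1 `CCc1cc2c(cc1C(=O)c1ccc(C(=O)O)cc1)C(C)(C)CCC2(C)C`. In an assay on CV-1 cells with retinoic acid receptor beta (Homo sapiens) as the target (a lower number here means that less compound is needed, a higher number that more compound is needed for the effect), compound 1 gives > 10000 nM, which is a limit of the assay rather than a number. Compound 2 `CCCc1cc2c(cc1C(=O)c1ccc(C(=O)O)cc1)C(C)(C)CCC2(C)C` is its homologue. In this assay compound 2 gives > 10000 nM, again a limit of the assay. The step that the two limits leave unreadable from compound 1 to compound 2 thus carries no readable size, and compound 2 stands only at the limit, where both values shown sit (the limit of > 10000 nM in this assay, at which 2 of the 2 values shown sit). Compound 3 `CC1(C)CCC(C)(C)c2cc(C(=O)c3ccc(C(=O)O)cc3)c(F)cc21` differs from compound 2 by fluoro in place of propyl on an aromatic carbon. For the measured compounds named here, no measured step bears on this change with a usable size, since a step that the two limits leave unreadable from compound 1 to compound 2 is unreadable between two limits. The expected step in this assay is therefore an at least 1.2-fold lower number from compound 2 to compound 3 (0.09 log units; that floor lies within the scatter), of uncertain direction, with a further limit the likeliest outcome. Compound 3 is estimated at 8000 nM, in the range 1000 nM to 30000 nM.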

Compound 3, half-maximal effective concentration: 395 nM
For compound 3 the middle estimate is 20-fold (1.31 log units) above the measured one, outside the stated range (below it).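

In this assay, for the compounds shown here, this position, an aromatic carbon ortho to a large group, gives the first readable value: fluoro in place of propyl gives an at least 25-fold lower number from compound 2 to compound 3 (1.40 log units; beyond the scatter), and fluoro in place of ethyl gives an at least 25-fold lower number from compound 1 to compound 3 (1.40 log units; beyond the scatter). Both steps are floors, and the step between the two alkyl compounds cannot be read. Compound 1 and compound 2 each stand at a limit of the assay, not at a number: the limit of > 10000 nM in this assay, at which 2 of the 3 values shown sit.

As far as these compounds go, whether the lower number follows from fluoro itself or from the loss of the ethyl or propyl chain remains open, and hydrogen, methyl, chloro or methoxy at this position would help separate the two. Going by these compounds alone, with compound 3 as the only numerical value, the series gives no order among substituents here.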